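A few compounds are considered here, and "the series" means these few. Any claim that something is new, unique, unknown or untested is made for them only; others in the source may bear on it.

- compound 1 `COc1ccc(/C=C/C(=O)c2ccccc2-c2ccc(F)cc2)cc1OC`: 81 nM
- compound 2 `COc1ccc(/C=C/C(=O)c2ccccc2-c2ccc(F)cc2)cc1B(O)O`: 21 nM
- compound 3 `COc1ccc(C(=O)/C=C/c2ccccc2-c2ccc(F)cc2)cc1`: 9000 nM

These three values come from a functional assay on CNE-2 cells (Homo sapiens) for antiproliferative activity, read by sulforhodamine B assay, with a stated time of 48 h; on this read-out higher numbers stand for weaker inhibition and lower numbers for stronger inhibition. Compound 3 gives the highest number of the set and is therefore the weakest inhibitor so far. Compound 3 at 9000 nM is far weaker than compound 1 at 81 nM, and the gap is wider still to compound 2 at 21 nM.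

Compound 4 `COc1ccc(C(=O)/C=C/c2ccccc2-c2ccc(F)nc2)cc1` changes compound 3 in one place: 6-fluoropyridin-3-yl in place of 4-fluorophenyl on an aromatic carbon. In plain terms, a 6-fluoropyridin-3-yl takes the place of a 4-fluorophenyl, so one ring carbon gives way to a nitrogen while the size of the group stays the same.

Among the measured compounds shown here, no measured step tests this swap. The only one available, a 3.9-fold lower number from compound 1 to compound 2 (0.59 log units; beyond the scatter), is a modest change at a different group, and both of its compounds keep the 4-fluorophenyl. It shows that a single replacement can move the number in this assay, but it gives no direction for this one. With so little to go on, no shift beyond the usual scatter is the best expectation, though the uncertainty is wide.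

The expected change is small, an estimated 1.1-fold lower number from compound 3 to compound 4 (0.05 log units; within the scatter). For compound 4 the estimate is 8000 nM, with an expected range from 2500 nM to 30000 nM.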

Compound 4, half-maximal inhibitory concentration: 13000 nM
Estimate against measurement, compound 4: 1.6-fold (0.21 log units) below, within the range that was stated.
By their numbers in this assay, from the lowest: compound 2; then compound 1; then compounds 3 and 4 (each within the scatter of the next).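

In this assay, the step from 4-fluorophenyl to 6-fluoropyridin-3-yl gives a 1.4-fold higher number from compound 3 to compound 4 (0.16 log units; within the scatter), so this replacement does not separate the two compounds. Among the compounds shown here, it is the first direct test at this position, on an aromatic carbon ortho to a large group, and it shows that one ring carbon can give way to a nitrogen, adding one hydrogen-bond acceptor at the same heavy-atom count, without a change that stands out from the scatter in this pair. Nothing measured here explains why the two numbers stay so close.

Whether the same swap would also leave the number undisturbed in compound 1 or compound 2, which both keep the 4-fluorophenyl, remains an open question, since a result from one pair need not carry over to a different core. Going by these compounds, it is also open how this position would respond to a larger change, such as an amine or a carboxylic acid in place of the fluorine on the ring.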